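This account rests on a few compounds, and the source may have more. Where it says the series, first, only, none or still open, it means among the compounds named here.

Measured so far in a functional assay on KMS-11 cells (Homo sapiens) for antiproliferative activity, read by CellTiter-Glo, with a stated time of 72 h; a lower number here means a stronger inhibitor, a higher number a weaker inhibitor:
compound 1 `COc1ccc(C(=O)N(Cc2ccncc2)Cc2cccc(OCCc3ccc(C)cc3)c2)cc1` gives 9100 nM;
compound 2 `COc1ccc(C(=O)N(Cc2ccncc2)Cc2cccc(OCc3ccc([N+](=O)[O-])cc3)c2)cc1` gives 15400 nM.

Compound 2 holds the highest of these two numbers, with compound 1 as its nearest neighbour through a 1.7-fold higher number from compound 1 to compound 2 (0.23 log units; within the scatter). Compound 3 `COc1ccc(C(=O)N(Cc2ccncc2)Cc2cccc(OCc3cccc([N+](=O)[O-])c3)c2)cc1` is its rearrangement: 3-nitrophenyl in place of 4-nitrophenyl on a saturated chain carbon bound to an oxygen on an aromatic ring. For the measured compounds named here, no measured step bears on this change directly; the single step on record, a 1.7-fold higher number from compound 1 to compound 2 (0.23 log units; within the scatter), concerns a different group and stays within the scatter, so it gives no direction. Compound 3 is therefore expected to stay close to compound 2, a step of a 1.0-fold lower number from compound 2 to compound 3 (0.01 log units; within the scatter). The estimate for compound 3 in this assay is 15000 nM, ranging from 6000 nM to 40000 nM.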

Compound 3, half-maximal inhibitory concentration: 19600 nM
Compound 3: middle estimate off by 1.3-fold (0.12 log units), on the low side, within the range that was stated.
By their numbers in this assay, from the lowest: compounds 1, 2 and 3 (each within the scatter of the next, the first and the last beyond it).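

In this assay moving the nitro group around its ring, from 4-nitrophenyl to 3-nitrophenyl, gives a 1.3-fold higher number from compound 2 to compound 3 (0.10 log units; within the scatter) and so leaves the two placements indistinguishable. For the compounds shown here, replacing 4-methylbenzyl with 3-nitrophenyl at this same place gives a 2.2-fold higher number from compound 1 to compound 3 (0.33 log units; beyond the scatter) and is the first step here to clear the scatter, though only modestly. No measurement on hand explains either step.

As far as these compounds go, whether an amine or a carboxylic acid in place of the nitro group on this ring would lower the number remains open.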